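Swapping sec-butyl for cyclopentyl on a cell-killing compound

The source may hold more compounds than are shown below. What is called first, only, known or untested is meant among the compounds shown, and "the series" means these compounds.

Measured in a functional assay on FaDu cells (Homo sapiens) for cytotoxicity, read by MTT assay, with a stated time of 72 h; a lower number here means that less compound is tolerated, a higher number that more compound is tolerated:
Compound 1 `COc1ccc(NC(=O)C(=O)c2cn(CC(C)(C)OC)c3ccccc23)cn1`: > 10000 nM
Compound 2 `CCC(C)n1cc(C(=O)C(=O)Nc2ccc(OC)nc2)c2ccccc21`: 68 nM

Compound 1 gives > 10000 nM, which is a limit of the assay and not a number. Among the compounds with values here, compound 2 gives 68 nM, the only true number so far, so there is no other number to rank it against.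

Within the data shown here, only one measured step bears on what follows. That step, an at least 140-fold lower number from compound 1 to compound 2 (2.16 log units; beyond the scatter), is large and beyond the scatter, and it puts sec-butyl in place of 2-methoxy-2-methylpropyl on an aromatic nitrogen. Its size rests on (the limit of > 10000 nM in this assay, at which 1 of the 2 values shown sits), so it marks a lower bound and not an exact distance.

Compound 3 `COc1ccc(NC(=O)C(=O)c2cn(C3CCCC3)c3ccccc23)cn1` changes that same place again, with cyclopentyl in place of sec-butyl on an aromatic nitrogen. Both groups are carbon only and carry no net charge. A single step says little about so small a change, so compound 2 at 68 nM remains the best guide, and no step beyond the scatter is expected in this assay. The expected change is a 1.1-fold lower number from compound 2 to compound 3 (0.05 log units; within the scatter). For compound 3 the estimated value is 60 nM, with an expected range of 15 nM to 250 nM.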

Compound 3, concentration lethal to 50% of the cells: 370 nM
Beside the measured number, compound 3's estimate is 6.2-fold (0.79 log units) below it; the measured number lies above the stated range.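

In this assay, this place on the aromatic nitrogen turns out to be sensitive even to a swap between two groups made only of carbon, neither carrying a net charge: there is a 5.4-fold higher number from compound 2 to compound 3 (0.74 log units; beyond the scatter), so the cyclopentyl ring cannot be treated as a simple stand-in for the open sec-butyl group. Even so, a large gap remains when cyclopentyl replaces 2-methoxy-2-methylpropyl, with an at least 27-fold lower number from compound 1 to compound 3 (1.43 log units; beyond the scatter), so the two carbon-only groups both sit far from the group in compound 1. The size of that second step is a lower bound and not an exact distance: the limit of > 10000 nM in this assay, at which 1 of the 3 values shown sits.

The compounds shown do not separate the effect of closing a ring from that of having one more carbon, a question that a smaller ring such as cyclobutyl or an open chain such as pentyl could address. They also leave open how a group carrying an amine or a carboxylic acid would fare at this place, and why compound 2 and compound 3 differ at all.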